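Aryl ether variation on a shared core

The source may hold more compounds than are shown below. What is called first, only, known or untested is meant among the compounds shown, and "the series" means these compounds.

Measured so far in a functional assay on cells for inhibition, with Murine T-cell line (Mus musculus) as the target; a higher number here means a weaker inhibitor, a lower number a stronger inhibitor:
Compound 1 `CC[C@@H]1/C=C(\C)C[C@H](C)C[C@H](OC)[C@H]2O[C@@](O)(C(=O)C(=O)N3CCCC[C@H]3C(=O)O[C@H](/C(C)=C/[C@@H]3CC[C@@H](O)[C@H](Oc4ccc(O)cc4)C3)[C@H](C)[C@@H](O)CC1=O)[C@H](C)C[C@@H]2OC` gives 0.9 nM.
Compound 2 `CC[C@@H]1/C=C(\C)C[C@H](C)C[C@H](OC)[C@H]2O[C@@](O)(C(=O)C(=O)N3CCCC[C@H]3C(=O)O[C@H](/C(C)=C/[C@@H]3CC[C@@H](Oc4ccc(C(F)(F)F)cc4)[C@H](OC)C3)[C@H](C)[C@@H](O)CC1=O)[C@H](C)C[C@@H]2OC` gives 35.8 nM.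

Compound 2 stands at the higher of the two numbers, beyond the scatter from compound 1; the two differ in more than one place, so only the values themselves are noted. Compound 3 `CC[C@@H]1/C=C(\C)C[C@H](C)C[C@H](OC)[C@H]2O[C@@](O)(C(=O)C(=O)N3CCCC[C@H]3C(=O)O[C@H](/C(C)=C/[C@@H]3CC[C@@H](Oc4cccc(C)c4)[C@H](OC)C3)[C@H](C)[C@@H](O)CC1=O)[C@H](C)C[C@@H]2OC` carries the change (3-methylphenyl in place of 4-(trifluoromethyl)phenyl on an oxygen on a saturated carbon). Going by the values given here, no step between measured compounds isolates this change, so the expectation rests on compound 2 alone. A modest move toward a lower number is expected, about at the edge of the scatter: a 2.4-fold lower number from compound 2 to compound 3 (0.38 log units; beyond the scatter). Compound 3 is estimated at 15 nM in this assay, within 4 nM to 60 nM.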

Compound 3, half-maximal inhibitory concentration: 5.4 nM
The estimate for compound 3 lay 2.8-fold (0.44 log units) above the measured number; the range from low to high includes it.
By their numbers in this assay, from the lowest: compound 1; then compound 3; then compound 2.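

On an oxygen on a saturated carbon, 3-methylphenyl in place of 4-(trifluoromethyl)phenyl gives a 6.6-fold lower number from compound 2 to compound 3 (0.82 log units; beyond the scatter) in this assay. This position is therefore sensitive to the choice of aryl group, and a change within the aryl ether alone moves the number beyond the scatter. No measurement at hand accounts for this step.

The step alters the substituent and its place on the ring together, so these compounds cannot separate the two. From the compounds shown here alone, how a plain phenyl, or a chain ending in an amine or a carboxylic acid, would read on this oxygen stays open.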